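Phenethyl ester on the shared core: expectation before measurement

The source may report more compounds than this note shows. Statements on the series, on what has been measured and on what is new or still open speak of the compounds shown alone.

Compound 3 `C/C=C1/[C@H](O[C@@H]2O[C@H](CO)[C@@H](O)[C@H](O)[C@H]2O)OC=C(C(=O)OC)[C@H]1CC(=O)OCCCC` is the butyl ester of the series. In a functional assay on SK-BR-3 cells (Homo sapiens) for antiproliferative activity, read by MTT assay, with a stated time of 72 h (a lower number here means a stronger inhibitor, a higher number a weaker inhibitor), compound 3 gives > 15000 nM, which is a limit of the assay and not a number. Compound 1 `C/C=C1/[C@H](O[C@@H]2O[C@H](CO)[C@@H](O)[C@H](O)[C@H]2O)OC=C(C(=O)OC)[C@H]1CC(=O)OCCc1ccc(OC)c(OC)c1`, with 3,4-dimethoxyphenyl in place of ethyl on the saturated chain carbon, gives > 15000 nM in this assay, again a limit. Compound 2 `C/C=C1/[C@H](O[C@@H]2O[C@H](CO)[C@@H](O)[C@H](O)[C@H]2O)OC=C(C(=O)OC)[C@H]1CC(=O)NCCC`, with propylamino in place of butoxy on the carbonyl carbon, gives > 20000 nM in this assay, also a limit. All three values therefore sit at limits: the limit of > 15000 nM in this assay, at which 2 of the 3 values shown sit, and (the limit of > 20000 nM in this assay, at which 1 of the 3 values shown sits).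

Compound 4 `C/C=C1/[C@H](O[C@@H]2O[C@H](CO)[C@@H](O)[C@H](O)[C@H]2O)OC=C(C(=O)OC)[C@H]1CC(=O)OCCc1ccccc1` differs from compound 3 as follows: phenyl in place of ethyl on a saturated chain carbon, two bonds along the chain from an oxygen next to a carbonyl group. For the measured compounds named here, the steps that bear on this change are a step that the two limits leave unreadable from compound 1 to compound 3 and a step that the two limits leave unreadable from compound 2 to compound 3, and neither has a readable size, since both ends stand at limits. Compound 1, which already carries an aromatic ring at the same place, is itself at a limit in this assay. Hence no step beyond the scatter is expected in this assay, and compound 4 is estimated at 20000 nM, within 8000 nM to 60000 nM. The expected step is a step that the limit leaves unreadable from compound 3 to compound 4.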

Compound 4, half-maximal inhibitory concentration: 11000 nM
For compound 4 the middle estimate is 1.8-fold (0.26 log units) above the measured one, and the stated range covers the measured number.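

In this assay compound 4 is the only compound shown that gives a number and not a limit, so the phenethyl ester places the shared core on a readable scale for the first time. Its steps are an at least 1.3-fold lower number from compound 3 to compound 4 (0.13 log units; that floor lies within the scatter), an at least 1.8-fold lower number from compound 2 to compound 4 (0.25 log units; that floor lies within the scatter) and an at least 1.3-fold lower number from compound 1 to compound 4 (0.13 log units; that floor lies within the scatter). These sizes are only floors, so neither phenyl in place of ethyl nor the loss of the two methoxy groups from the 3,4-dimethoxyphenyl ring is shown to give a change beyond the scatter, since the far end of the first and third steps stands at a limit: the limit of > 15000 nM in this assay, at which 2 of the 4 values shown sit.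

As far as these compounds go, the true size of all three steps stays open. A phenylpropyl ester, or an amine or a carboxylic acid on the phenyl ring, would show whether the number of compound 4 can move clearly in either direction.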